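Compound 3 after two limit values

The source may report more compounds than this note shows. Statements on the series, on what has been measured and on what is new or still open speak of the compounds shown alone.

Measured in a functional assay on A549 cells (Homo sapiens) for antiproliferative activity, read by spectrophotometry, with a stated time of 2 days; a lower number here means a stronger inhibitor of growth, a higher number a weaker inhibitor of growth:
- Compound 1 `COc1ccc(Nc2ncc(C(F)(F)F)c(N3Cc4cccc(N(C)S(C)(=O)=O)c4C3)n2)cc1C(F)(F)F`: > 30000 nM, a limit
- Compound 2 `Cc1ccc(Nc2ncc(C(F)(F)F)c(N3Cc4cccc(N(C)S(C)(=O)=O)c4C3)n2)c(Cl)c1`: > 30000 nM, a limit

Compound 2 gives no number, only the limit > 30000 nM. Within the data shown here, the one measured step is a step that the two limits leave unreadable from compound 1 to compound 2, and the other evidence is the limit of > 30000 nM in this assay, at which 2 of the 2 values shown sit. Compound 3 `COc1cc(Nc2ncc(C(F)(F)F)c(N3Cc4cccc(N(C)S(C)(=O)=O)c4C3)n2)c(OC)cc1Cl` carries 4-chloro-2,5-dimethoxyphenyl in place of 2-chloro-4-methylphenyl on a nitrogen on an aromatic ring. Among the measured compounds shown here, with only that unreadable step, a step that the two limits leave unreadable from compound 1 to compound 2, no size or direction can be drawn from the data, so compound 3 is expected to stay near the same limit in this assay. The expected step is a number no higher from compound 2 to compound 3 (the limit leaves the size open). Compound 3 is estimated at 30000 nM, with an expected range of 10000 nM to 60000 nM.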

Compound 3, concentration for 50% growth inhibition: 7300 nM
Beside the measured number, compound 3's estimate is 4.1-fold (0.61 log units) above it; the whole stated range lies above it.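

In this assay, this position on the nitrogen now shows a readable effect of the group it carries: 4-chloro-2,5-dimethoxyphenyl gives an at least 4.1-fold lower number from compound 2 to compound 3 (0.61 log units; beyond the scatter), and it gives an at least 4.1-fold lower number from compound 1 to compound 3 (0.61 log units; beyond the scatter). On these data alone, both steps start from a limit, so their true sizes stay open, and the step between compound 1 and compound 2 cannot be read. Compound 3 alone gives a number rather than a limit: the limit of > 30000 nM in this assay, at which 2 of the 3 values shown sit.

The compounds shown leave open which part of 4-chloro-2,5-dimethoxyphenyl carries the step. They also leave open how an amine or a carboxylic acid on this ring would read.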